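Shortening the chain of compound 3

The source may report more compounds than this note shows. Statements on the series, on what has been measured and on what is new or still open speak of the compounds shown alone.

Values measured so far in a toxicity assay on MRC5 cells (Homo sapiens) for inhibition, read by MTT assay, with a stated time of 72 h; a higher number here means a weaker inhibitor, a lower number a stronger inhibitor:

Compound 1 `O=S(=O)(O)Oc1ccc(CCO)cc1` gives 106000 nM
Compound 2 `CCCCCCCCCCCCCCCC(=O)OCCc1ccc(O)c(O)c1` gives > 50000 nM (a limit of the assay, not a number)
Compound 3 `CCCCCCCCCCCC(=O)OCCc1ccc(O)cc1` gives 67200 nM

Only two of these three results are true numbers. Compound 3, at 67200 nM, has the lower of the two, but compound 1, at 106000 nM, lies within the usual scatter of it, so the pair cannot be ranked. Compound 2 stands at the limit of > 50000 nM and offers no number to compare.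

The next compound is compound 4 `CCCCCCCC(=O)OCCc1ccc(O)cc1`, which has a shorter chain than compound 3. The change is hydrogen in place of butyl on a saturated chain carbon, seven bonds along the chain from a carbonyl carbon.

Going by the values given here, no pair of measured compounds shows what such a change does in this assay, so the expectation rests only on compound 3 at 67200 nM as the starting point. The expected step of a 1.3-fold higher number from compound 3 to compound 4 (0.13 log units; within the scatter) stays within the scatter, with at most a slight drift toward a weaker inhibitor. For compound 4 the estimated value is 90000 nM, with an expected range from 40000 nM to 220000 nM.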

Compound 4, half-maximal inhibitory concentration: 133000 nM
For compound 4 the middle estimate is 1.5-fold (0.17 log units) below the measured one; low and high end bracket the measured number.
By their numbers in this assay, from the lowest: compounds 3, 1 and 4 (each within the scatter of the next).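

Going by these compounds alone, this is the first step in this assay between two measured compounds that differ in one place: hydrogen in place of butyl on a saturated chain carbon, seven bonds along the chain from a carbonyl carbon, gives a 2.0-fold higher number from compound 3 to compound 4 (0.30 log units; within the scatter). On this single pair, then, removing the butyl leaves a difference that cannot be told from the scatter, and one step gives no trend with chain length. Compound 2 gives a limit and not a number, so it cannot be placed in the order of the other compounds: the limit of > 50000 nM in this assay, at which 1 of the 4 values shown sits.

The compounds shown leave open whether a longer chain than that of compound 3, or a chain ending in an amine or a carboxylic acid, would move the number beyond the scatter. Also open, as far as these compounds go, is whether an amide in place of the ester would give a different reading in this assay.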